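The compounds below may be only part of what the source reports. "The series", "measured", "known", "first", "only" and "open" are said of these compounds alone.

Compound 1 `COc1cc(F)c(NC(=O)c2ccncc2)cc1Nc1nccc(-c2cn(C)c3ccccc23)n1` gives 4370 nM in a functional assay on NCI-H1975 cells (Homo sapiens) for antiproliferative activity, read by MTT assay, with a stated time of 72 h; a higher number here means a weaker inhibitor, a lower number a stronger inhibitor; compound 2 `COc1cc(F)c(NC(=O)c2ccnc(O)c2)cc1Nc1nccc(-c2cn(C)c3ccccc23)n1` gives 5920 nM; compound 3 `COc1cc(N(C)CCN(C)C)c(NC(=O)c2ccnc(O)c2)cc1Nc1nccc(-c2cn(C)c3ccccc23)n1` gives 12000 nM.

Among these three, compound 3 stands at the highest number, with compound 2 nearest and compound 1 furthest. Compound 4 `COc1cc(N(C)CCN(C)C)c(NC(=O)c2ccncn2)cc1Nc1nccc(-c2cn(C)c3ccccc23)n1` differs from compound 3 by pyrimidin-4-yl in place of 2-hydroxypyridin-4-yl on a carbonyl carbon. Within the data shown here, the only measured step that touches the ring on the carbonyl carbon is a 1.4-fold higher number from compound 1 to compound 2 (0.13 log units; within the scatter), which put the hydroxy in and stayed within the scatter; taking it out again, along with the exchange of the ring, is therefore expected to shift this assay by little, if anything, and no step beyond the scatter is expected. Compound 4 is estimated at 10000 nM, within 4000 nM to 25000 nM, meaning an expected step of a 1.2-fold lower number from compound 3 to compound 4 (0.08 log units; within the scatter).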

Compound 4, half-maximal inhibitory concentration: 1560 nM
Compound 4: middle estimate off by 6.4-fold (0.81 log units), on the high side, and the stated range ends above it.
By their numbers in this assay, from the lowest: compound 4; then compounds 1 and 2 (each within the scatter of the next); then compound 3.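

Among these compounds, the ring on the carbonyl carbon carries more weight in this assay than the earlier compounds showed: pyrimidin-4-yl in place of 2-hydroxypyridin-4-yl gives a 7.7-fold lower number from compound 3 to compound 4 (0.89 log units; beyond the scatter), whereas the only earlier change at this ring, a 1.4-fold higher number from compound 1 to compound 2 (0.13 log units; within the scatter), stayed within the scatter. No measurement shown accounts for this step.

Compound 4 both loses the hydroxy and gains a second ring hetero atom, and the compounds shown do not separate these two changes. They also leave open whether an amine on the pyrimidine ring would retain the gain, and whether it would persist with fluoro on the shared core.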